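Tosyl Cap on an Aniline Nitrogen in a Growth Assay

A few compounds are considered here, and "the series" means these few. Any claim that something is new, unique, unknown or untested is made for them only; others in the source may bear on it.

Of the compounds shown here, two that share one core have been tested in a functional assay on SK-MEL-2 cells (Homo sapiens) for inhibition, read by sulforhodamine B assay; on this read-out higher numbers stand for weaker inhibition of growth and lower numbers for stronger inhibition of growth. Compound 1 `Nc1ccc(CNC(=O)CC2c3ccccc3N=C(N3CCCCC3)N2c2ccccc2)cc1` carries a free amino group on its outer ring, and in this assay compound 1 gives 30700 nM. Compound 2 `CCN1C(N2CCCCC2)=Nc2ccccc2C1CC(=O)NCc1ccccc1` replaces that outer ring with a plain benzyl group and an ethyl group on the core, and in this assay compound 2 gives 42500 nM. The two numbers sit close together, and their gap lies within the usual scatter, so neither compound can be set apart from the other on the evidence so far; both inhibit growth only weakly.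

Compound 3 `Cc1ccc(S(=O)(=O)Nc2ccc(CNC(=O)CC3c4ccccc4N=C(N4CCCCC4)N3c3ccccc3)cc2)cc1` differs from compound 1 in one place: (4-methylphenyl)sulfonyl in place of hydrogen on a nitrogen on an aromatic ring. Among the measured compounds shown here, no measured pair shows what such a change does here, so any expectation rests on the weak starting point alone. The expected step, a 2.0-fold lower number from compound 1 to compound 3 (0.31 log units; beyond the scatter), is a modest move toward stronger growth inhibition, with a fair chance of no change beyond the scatter. Compound 3 is therefore expected to give about 15000 nM, with a likely range from 4000 nM to 50000 nM.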

Compound 3, concentration for 50% growth inhibition: 2700 nM
For compound 3 the middle estimate is 5.6-fold (0.74 log units) above the measured one; the measured number lies below the stated range.
By their numbers in this assay, from the lowest: compound 3; then compounds 1 and 2 (each within the scatter of the next).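

In this assay, among the compounds shown here, the swap of hydrogen for (4-methylphenyl)sulfonyl on the nitrogen on the aromatic ring gives an 11-fold lower number from compound 1 to compound 3 (1.06 log units; beyond the scatter) and is the first change in one place that can be read. For the compounds shown here, the two earlier compounds could not be told apart and offered no such step, whereas this result shows that the free amino group is not needed for growth inhibition in this assay and that capping it with this much larger group goes with clearly stronger inhibition. Nothing measured here explains why the step is so large.

A single step cannot show which part of the new group matters: the methyl group, the aromatic ring or the sulfonyl link. As far as these compounds go, whether phenylsulfonyl without the methyl, the smaller methanesulfonyl or an acetyl group on the same nitrogen would give a similar step remains open, as does whether the gain would hold with an ethyl group in place of the phenyl group on the core.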